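Compound 3 to compound 4: changing one phenyl group

The source may hold more compounds than are shown below. What is called first, only, known or untested is meant among the compounds shown, and "the series" means these compounds.

Going by the values given here, in a physicochemical assay for permeability, using PAMPA (a lower number here means that the compound crosses the layer more slowly, a higher number that the compound crosses the layer faster), compound 3 (`Cc1cccc(C)c1-c1nc(CN2CCC(C(=O)NCCCN3C[C@H](C)C[C@H](C)C3)CC2)c(C)o1`) gives 254 10^-6 cm/s as the only real number in this small series. Compound 2 (`Cc1oc(-c2c(Br)cccc2Br)nc1CN1CCC(C(=O)NCCCN2C[C@H](C)C[C@H](C)C2)CC1`) gives < 1 10^-6 cm/s and this is a limit of the assay, not a number. For compound 1 (`Cc1oc(-c2ccc(F)cc2)nc1CN1CCC(C(=O)NCCCN2C[C@H](C)C[C@H](C)C2)CC1`) the result stands as "not determined" (no result reported) here. Compound 4 (`COc1ccc(-c2nc(CN3CCC(C(=O)NCCCN4C[C@H](C)C[C@H](C)C4)CC3)c(C)o2)cc1OC`) carries 3,4-dimethoxyphenyl in place of 2,6-dimethylphenyl (3,4-dimethoxyphenyl in place of 2,6-dimethylphenyl on an aromatic carbon). The measured step of an at least 250-fold higher number from compound 2 to compound 3 (2.40 log units; beyond the scatter) is large and falls at this same place, so a swap here can move the number far. With compound 3 so high at 254 10^-6 cm/s there is more room to fall than to rise. A clear drop is therefore expected, with a 6.4-fold lower number from compound 3 to compound 4 (0.80 log units; beyond the scatter) as the estimated step in this assay on this single precedent. For compound 4 the estimated value is 40 10^-6 cm/s with an expected range from 3 10^-6 cm/s to 250 10^-6 cm/s in this rough forecast.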

Compound 4, apparent permeability: 81.9 10^-6 cm/s
The estimate for compound 4 lay 2.0-fold (0.31 log units) below the measured number, within the range that was stated.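

In this assay there is a 3.1-fold lower number from compound 3 to compound 4 (0.49 log units; beyond the scatter), so a phenyl group with a different pattern, now carrying hydrogen-bond acceptors, still gives a real number at this position. There is also an at least 81-fold higher number from compound 2 to compound 4 (1.91 log units; beyond the scatter), which leaves compound 2 apart from both compounds with real numbers. The entry for compound 2 remains a limit of the assay, not a number: the limit of < 1 10^-6 cm/s in this assay, at which 1 of the 4 values shown sits.

From the compounds shown here alone, whether the fall follows the methoxy groups or their place on the ring stays open; 2,6-dimethoxyphenyl or 3,4-dimethylphenyl would separate the two. How an amine or a carboxylic acid on this phenyl ring would read is open too.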